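Terminal aromatic ring variation on the shared core

The source may hold more compounds than are shown below. What is called first, only, known or untested is meant among the compounds shown, and "the series" means these compounds.

Measured in a functional assay on HEK293 cells for agonist activity at Bombesin receptor subtype-3 (Homo sapiens), read by luminescence and calcium flux, with a stated time of 10 min; on this read-out lower numbers stand for an effect already at smaller amounts and higher numbers for an effect only at larger amounts of compound:
compound 1, `CCC(C)(C)Cc1c[nH]c(CCc2ccc(-c3cccc(N)n3)cc2)n1`, 37 nM
compound 2, `CCC(C)(C)Cc1c[nH]c(CCc2ccc(-c3cnccn3)cc2)n1`, 431 nM
compound 3, `CCC(C)(C)Cc1c[nH]c(CCc2ccc(-n3ccnn3)cc2)n1`, 641 nM

Compound 2 stands second highest of the three numbers: to compound 3 the step is a 1.5-fold higher number from compound 2 to compound 3 (0.17 log units; within the scatter), while the step of a 12-fold higher number from compound 1 to compound 2 (1.07 log units; beyond the scatter) lies beyond the scatter. The unmeasured compound 4, `CCC(C)(C)Cc1c[nH]c(CCc2ccc(-c3cccc(C)n3)cc2)n1`, differs from compound 2 in one place: 6-methylpyridin-2-yl in place of pyrazin-2-yl on an aromatic carbon.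

Among the measured compounds shown here, the steps that bear on this change are those leaving the aminopyridinyl of compound 1: a 12-fold higher number from compound 1 to compound 2 (1.07 log units; beyond the scatter) and a 17-fold higher number from compound 1 to compound 3 (1.24 log units; beyond the scatter), both large. For the measured compounds named here, compound 4 returns to a pyridin-2-yl ring but carries a methyl where compound 1 carries an amino group, so no measured step covers the change exactly. A step back toward compound 1 is expected, though only part of the way, because the amino group of compound 1 is absent and its 37 nM need not be reached.

For compound 4 the expected step is a 3.3-fold lower number from compound 2 to compound 4 (0.52 log units; beyond the scatter). Compound 4 is estimated at 130 nM, with a range from 40 nM to 450 nM.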

Compound 4, half-maximal effective concentration: 105 nM
Compound 4: middle estimate off by 1.2-fold (0.09 log units), on the high side; the measured number falls inside the stated range.
By their numbers in this assay, from the lowest: compound 1; then compound 4; then compounds 2 and 3 (each within the scatter of the next).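

A 6-methylpyridin-2-yl ring gives a clear gain over both other rings lacking the amino group (a 4.1-fold lower number from compound 2 to compound 4 (0.61 log units; beyond the scatter) and a 6.1-fold lower number from compound 3 to compound 4 (0.79 log units; beyond the scatter)), so a number well below those of compound 2 and compound 3 does not depend on an amino group. The amino group still counts, as methyl in place of amino is a modest but real loss (a 2.8-fold higher number from compound 1 to compound 4 (0.45 log units; beyond the scatter)), smaller than the steps from compound 1 to the pyrazin-2-yl and triazolyl rings. Nothing available gives a reason for these steps.

Open, going by these compounds, is how much of the gain belongs to the pyridin-2-yl ring and how much to the methyl, which a pyridin-2-yl ring without any substituent would separate. Equally open, on these data alone, is whether a methoxy, a chlorine or a dimethylamino group in place of the methyl would come closer to compound 1.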